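Cyclic amine swap on the amidine carbon of compound 2

The source may hold more compounds than are shown below. What is called first, only, known or untested is meant among the compounds shown, and "the series" means these compounds.

The study takes two measured cytotoxicity values as its starting point. Compound 1 `COc1ccc(CNC(=O)CC2c3ccccc3N=C(N(C)CCCCCN(C)C)N2c2ccc(-c3ccccc3)cc2)cc1` gives 2520 nM in a functional assay on cells (Homo sapiens) for cytotoxicity, read by MTT assay, with a stated time of 48 h (a lower number here means a stronger inhibitor, a higher number a weaker inhibitor), and compound 2 `CN(C)CCCCN(C)C1=Nc2ccccc2C(CC(=O)NCc2ccccc2)N1c1ccc(-c2ccccc2)cc1` gives 3970 nM in the same assay. Compound 2 carries the highest of the two numbers, but its nearest neighbour, compound 1, sits within the usual scatter, so the two cannot be ordered against each other.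

From compound 2 the account moves to compound 3 `CN(C)CCN1CCN(C2=Nc3ccccc3C(CC(=O)NCc3ccccc3)N2c2ccc(-c3ccccc3)cc2)CC1`, which is not yet measured. The change is 4-(2-(dimethylamino)ethyl)piperazin-1-yl in place of (4-(dimethylamino)butyl)(methyl)amino on a carbon with a double bond to nitrogen. A 4-(2-(dimethylamino)ethyl)piperazin-1-yl group thus replaces the (4-(dimethylamino)butyl)(methyl)amino group on the carbon with a double bond to nitrogen of the shared core.

Among the measured compounds shown here, no measured pair in this set separates the effect of such a change, so the expectation rests on compound 2 alone. Compound 3 is expected to stay close to compound 2, with the step of a 1.0-fold higher number from compound 2 to compound 3 (0.00 log units; within the scatter) estimated to lie within the scatter in either direction. The estimate for compound 3 in this assay is 4000 nM, with a range from 1500 nM to 11000 nM.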

Compound 3, half-maximal inhibitory concentration: 2390 nM
Beside the measured number, compound 3's estimate is 1.7-fold (0.22 log units) above it; measured number inside the range.
By their numbers in this assay, from the lowest: compounds 3, 1 and 2 (each within the scatter of the next).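

The swap gives the first step read at this position, on a carbon with a double bond to nitrogen, between two ring nitrogen atoms: in this assay, putting 4-(2-(dimethylamino)ethyl)piperazin-1-yl in place of (4-(dimethylamino)butyl)(methyl)amino gives a 1.7-fold lower number from compound 2 to compound 3 (0.22 log units; within the scatter) and so stays inside the scatter. The position therefore accepts a group with one six-membered non-aromatic ring with 2 hetero atoms in place of a group with no ring, and the two numbers cannot be ordered against each other, so this change shows no measurable gain or loss in this assay. No supporting data bear on what lies behind this result.

The compounds shown leave open whether any group at this carbon can move the number beyond the scatter, since both groups here end in a dimethylamino group. A morpholin-4-yl ring with no side chain, or a chain ending in a carboxylic acid instead of that amine, would test whether the terminal amine matters at this position.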